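Weak inhibitors at the edge of measurement

The source may report more compounds than this note shows. Statements on the series, on what has been measured and on what is new or still open speak of the compounds shown alone.

The three measured compounds share one core and differ in the group borne on the five-membered ring. Compound 1 `CCOC(=O)C1=Cc2ccccc2OC1(OCc1cc(-c2ccc(OC)cc2)no1)C(F)(F)F` reaches only a limit in a functional assay on HeLa cells (Homo sapiens) for inhibition, read by MTT assay, with a stated time of 24 h (a higher number here means a weaker inhibitor, a lower number a stronger inhibitor), giving > 150000 nM. Compound 3 `O=C(O)C1=Cc2ccccc2OC1(OCc1cc(-c2ccc([N+](=O)[O-])cc2)no1)C(F)(F)F` likewise gives only the limit > 150000 nM in this assay. Among the measured compounds shown here, compound 2 `CCOC(=O)C1=Cc2ccccc2OC1(OCc1cn(CC(=O)Nc2ccc(C)cc2)nn1)C(F)(F)F` is the one compound with a number: in this assay compound 2 gives 67400 nM, which stands apart from the limit of > 150000 nM in this assay, at which 2 of the 3 values shown sit. For the measured compounds named here, no step between two measured compounds can be described, since each pair differs in more than one place.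

Compound 4 `CCOC(=O)C1=Cc2ccccc2OC1(OCc1cn(-c2ccc(F)c(Cl)c2)nn1)C(F)(F)F` is not yet measured. It differs from compound 2 in this way: 3-chloro-4-fluorophenyl in place of ((4-methylphenyl)carbamoyl)methyl on an aromatic nitrogen. Going by the values given here, nothing among the measured compounds tells how this change acts, so the step of a 1.2-fold higher number from compound 2 to compound 4 (0.07 log units; within the scatter) is expected to be small in either direction, within the scatter. In this assay compound 4 is therefore estimated at 80000 nM, between 25000 nM and 150000 nM, with a real chance that only a limit is reported.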

Compound 4, half-maximal inhibitory concentration: 22700 nM
Compound 4: middle estimate off by 3.5-fold (0.55 log units), on the high side; the whole stated range lies above it.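

Placing 3-chloro-4-fluorophenyl in place of ((4-methylphenyl)carbamoyl)methyl on an aromatic nitrogen gives a 3.0-fold lower number from compound 2 to compound 4 (0.47 log units; beyond the scatter) in this assay, which shows that this position responds to change, something no earlier pair could show. The entering group has fewer heavy atoms and no hydrogen-bond donor or acceptor, so the carbamoyl link is not required for a measured value here. Compound 1 and compound 3, whose five-membered ring differs, remain at a limit: the limit of > 150000 nM in this assay, at which 2 of the 4 values shown sit.

This single change replaces the whole group, so the compounds shown cannot separate the part played by the chlorine, the fluorine or the loss of the carbamoyl link. Going by these compounds, it also remains open how a plain phenyl, or a phenyl bearing an amine or a carboxylic acid, would read at this position.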